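The source may hold more compounds than are shown below. What is called first, only, known or untested is meant among the compounds shown, and "the series" means these compounds.

Two compounds of the series have numbers in a functional assay with metabotropic glutamate receptor 2 (Homo sapiens) as the target, read by GTPgammaS binding, in the presence of a further agent that is not named here; a lower number here means that less compound is needed, a higher number that more compound is needed for the effect. Compound 2 `c1ccc(NCc2cncnc2)cc1` gives 9.6 uM, the higher of the two. For the measured compounds named here, compound 1 `CCCC(C)Oc1cccc(NCc2cnc3ccccc3c2)c1` gives 4.3 uM in this assay, a gap stated as beyond the scatter; no single-point step links the two. Compound 3 `c1ccc(Cc2cccc(NCc3cncnc3)c2)cc1` differs from compound 2 by benzyl in place of hydrogen on an aromatic carbon. Going by the values given here, no measured step is on hand for this change; only compound 1, carrying its own group on the same ring, gives the lower number. A modest downward step is expected, a 2.1-fold lower number from compound 2 to compound 3 (0.33 log units; beyond the scatter). Compound 3 is therefore estimated at 4.5 uM in this assay, within 1.5 uM to 13 uM.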

Compound 3, concentration for half-maximal effect: 0.71 uM
For compound 3 the middle estimate is 6.3-fold (0.80 log units) above the measured one; measured number below the stated range.
By their numbers in this assay, from the lowest: compound 3; then compound 1; then compound 2.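

Benzyl in place of hydrogen on an aromatic carbon, meta to a group of 8 heavy atoms, gives a 14-fold lower number from compound 2 to compound 3 (1.13 log units; beyond the scatter) in this assay as the first single-point step measured in this series. This position therefore accepts a group carrying a second aromatic ring, and the number falls by a large step. No measurement at hand accounts for the size of this step.

On these data alone, it remains open whether a smaller group such as methyl, or an amine on the same carbon, gives a comparable step. As far as these compounds go, the effect of benzyl at other carbons of this ring also remains open.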